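Ureas With a Methylsulfanyl Pyridine Core: Methyl for Methylsulfonyl

A few compounds are considered here, and "the series" means these few. Any claim that something is new, unique, unknown or untested is made for them only; others in the source may bear on it.

The measured compounds:
- Compound 1, `CSc1nc(C)nc(SC)c1NC(=O)N(Cc1ccc(Oc2ccc(F)cc2)cc1)C1CCCCCC1`, gives 56 nM in an assay for inhibition of acyl-CoA:cholesterol acyltransferase (Oryctolagus cuniculus), using microsomes; on this read-out lower numbers stand for stronger inhibition and higher numbers for weaker inhibition.
- Compound 2, `CSc1cc(C)nc(S(C)(=O)=O)c1NC(=O)N(Cc1ccc(Oc2ccc(F)cc2)cc1)C1CCCCCC1`, gives 78 nM in this assay.

Compound 2 has the higher of the two numbers, but the gap between compound 2 and compound 1 is within the scatter of repeated measurements, so the two values show no real difference. Compound 1 and compound 2 differ in more than one place, so nothing can be said about any single change between them.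

Compound 3, `CSc1cc(C)nc(C)c1NC(=O)N(Cc1ccc(Oc2ccc(F)cc2)cc1)C1CCCCCC1`, has not been measured. It differs from compound 2 in one place: methyl in place of methylsulfonyl on an aromatic carbon. Among the measured compounds shown here, no step between measured compounds of this study shows what such a change does; the two values at hand only show that a methylsulfonyl group on this core is compatible with a number near that of compound 1. The expected step from compound 2 to compound 3 is a 1.4-fold lower number from compound 2 to compound 3 (0.15 log units; within the scatter), within the scatter in either direction. Compound 3 is therefore expected to give 55 nM in this assay, in a range from 15 nM to 200 nM.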

Compound 3, half-maximal inhibitory concentration: 90 nM
The estimate for compound 3 lay 1.6-fold (0.21 log units) below the measured number; the range from low to high includes it.
By their numbers in this assay, from the lowest: compounds 1, 2 and 3 (each within the scatter of the next).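

In this assay, among the compounds shown here, the first direct reading of this change is a 1.2-fold higher number from compound 2 to compound 3 (0.06 log units; within the scatter), so on the aromatic carbon next to the ring nitrogen and ortho to a large group, methyl and methylsulfonyl show no real difference, although methylsulfonyl has 4 heavy atoms and 2 hydrogen-bond acceptors and methyl has 1 heavy atom and none. The larger replacement on the amide-type nitrogen, a group of 10 heavy atoms with a six-membered aromatic ring with 1 hetero atom in place of a group of 11 heavy atoms with a six-membered aromatic ring with 2 hetero atoms, gives a 1.6-fold higher number from compound 1 to compound 3 (0.21 log units; within the scatter), which also shows no real difference. No measurement at hand bears on why these numbers stay so close.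

Since the compounds shown place only methyl and methylsulfonyl at this position, it remains open whether a hydrogen, an amine, a carboxylic acid or a longer chain such as propyl would be accepted as well. On these data alone, all three compounds also share the rest of the urea, so what a change there would do in this assay remains open too.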